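The source may report more compounds than this note shows. Statements on the series, on what has been measured and on what is new or still open speak of the compounds shown alone.

Measured so far:
Compound 1 `CCCCCN1CCN(c2nc3ccccc3n2CCOCC)CC1` — in a functional assay on ileum for inhibition of histamine H1 receptor (Cavia porcellus) (a higher number here means a weaker inhibitor, a lower number a stronger inhibitor), compound 1 gives 30 nM.
Compound 2 `CCOCCn1c(N2CCN(CC)CC2)nc2ccccc21` — in this assay compound 2 gives 18 nM.

For the measured compounds named here, compound 2 and compound 1 lie within the scatter of each other; the only step so far, a 1.7-fold lower number from compound 1 to compound 2 (0.22 log units; within the scatter), concerns the chain carbon, not the ring nitrogen. Compound 3 `CCOCCn1c(N2CCN(c3ccccc3)CC2)nc2ccccc21` differs from compound 2 by phenyl in place of ethyl on an amine nitrogen in a ring. Going by the values given here, no measured step touches this position, so the data give no direction; the entering group is larger in heavy atoms than the leaving one, and a modest weakening is expected, a 3.3-fold higher number from compound 2 to compound 3 (0.52 log units; beyond the scatter). Compound 3 is therefore estimated at 60 nM in this assay, range 15 nM to 300 nM.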

Compound 3, half-maximal inhibitory concentration: > 10000 nM
Compound 3: only a limit was reported; the forecaster's own chance of this, stated with the estimate: 5%; at least 160-fold (2.22 log units) between middle value and limit.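

In this assay compound 3 gives > 10000 nM, which is a limit of the assay and not a number: the limit of > 10000 nM in this assay, at which 1 of the 3 values shown sits.

At the amine nitrogen in a ring, the change to phenyl is a large step from either alkyl group: an at least 550-fold higher number from compound 2 to compound 3 (2.74 log units; beyond the scatter) with phenyl in place of ethyl, and an at least 330-fold higher number from compound 1 to compound 3 (2.52 log units; beyond the scatter) with phenyl in place of pentyl. Compound 1 and compound 2 lie within the scatter of each other, so this position separates phenyl from both alkyl groups shown, but not those two from each other.

Still open, going by these compounds, is whether a cyclohexyl or a benzyl group on this nitrogen would give the same result as phenyl. On these data alone, the true size of both steps also stays open, since each ends at a limit.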